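Swapping a Furan Ring for a Pyridine Ring

This account rests on a few compounds, and the source may have more. Where it says the series, first, only, none or still open, it means among the compounds named here.

Among the compounds with values here, compound 2 `Oc1cccc(-c2cc(-c3ccc(Cl)cc3)nc(-c3ccco3)c2)c1` gives 11400 nM in a functional assay on DU-145 cells (Homo sapiens) for cytotoxicity, read by CCK-8 assay and cell counting, with a stated time of 2 days (a lower number here means a stronger inhibitor, a higher number a weaker inhibitor), which places it level with the only other measured compound: compound 1 `Oc1cccc(-c2cc(-c3ccccc3)nc(-c3ccc(Cl)cc3)c2)c1` gives 11200 nM in this assay, and the step of a 1.0-fold higher number from compound 1 to compound 2 (0.01 log units; within the scatter) falls within the scatter. Compound 3 `Oc1cccc(-c2cc(-c3ccncc3)nc(-c3ccc(Cl)cc3)c2)c1` differs from compound 2 by a single change, (pyridin-4-yl in place of furan-2-yl on an aromatic carbon). Within the data shown here, the one measured step at this position, a swap of one aromatic ring for another, left the number essentially unchanged, so a similar outcome is expected here. Compound 3 is therefore expected to show a step of a 1.0-fold lower number from compound 2 to compound 3 (0.02 log units; within the scatter) in this assay, not beyond the scatter. Compound 3 is estimated at 11000 nM, ranging from 4000 nM to 30000 nM.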

Compound 3, half-maximal inhibitory concentration: 2510 nM
The estimate for compound 3 lay 4.4-fold (0.64 log units) above the measured number; the measured number lies below the stated range.
By their numbers in this assay, from the lowest: compound 3; then compounds 1 and 2 (each within the scatter of the next).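

Swapping one aromatic ring for another at this position is not always neutral in this assay: furan-2-yl and phenyl gave values within the scatter of each other, yet pyridin-4-yl gives a 4.5-fold lower number from compound 2 to compound 3 (0.66 log units; beyond the scatter) and a 4.5-fold lower number from compound 1 to compound 3 (0.65 log units; beyond the scatter) in the same direction. The drop therefore appears with pyridin-4-yl whichever of those two rings it replaces. No measurement here explains this difference.

The compounds shown leave open whether the place of the nitrogen within the ring matters, as pyridin-3-yl or pyridin-2-yl would show. They also leave open how an amine or a carboxylic acid on the pyridin-4-yl ring would fare.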